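The source may hold more compounds than are shown below. What is called first, only, known or untested is meant among the compounds shown, and "the series" means these compounds.

For the measured compounds named here, compound 1 `O=C(O)c1cccc(-c2csc(-c3ccccc3F)n2)c1` is the one compound of the three that returns a number in an ADME assay on microsomes from liver (Homo sapiens) for metabolic stability, read by LC-MS, using NADPH; a lower number here means that the compound disappears faster, a higher number that the compound lasts longer: compound 1 gives 3.14 h. Compound 2 `COC(=O)c1cccc(-c2cnc(Nc3cccc(F)c3)o2)c1` reaches only a limit of the assay in this assay, where compound 2 gives < 0.0167 h. Compound 3 `COC(=O)c1cccc(-c2cnc(Nc3ccc(F)cc3)o2)c1` likewise reaches only a limit in this assay, where compound 3 gives < 0.0167 h. The step that the two limits leave unreadable from compound 2 to compound 3 therefore cannot be read, since both values sit at the limit of < 0.0167 h in this assay, at which 2 of the 3 values shown sit. Compound 4 `CNC(=O)c1cccc(-c2cnc(Nc3ccc(F)cc3)o2)c1` differs from compound 3 by methylamino in place of methoxy on a carbonyl carbon. Going by the values given here, no measured pair among the three compounds shares this change, so no measured step bears on it directly, and the position of compound 3 is known only as a limit. The step of an at least 5.9-fold higher number from compound 3 to compound 4 (0.77 log units; beyond the scatter) that the estimate implies is thus an expectation resting on that limit alone. On that basis compound 4 is expected to give 0.1 h in this assay, with a range from 0.0167 h to 0.6 h, and it may again be reported only as a limit.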

Compound 4, half-life: 0.423 h
Compound 4: the middle estimate sits 4.2-fold (0.63 log units) below what was measured; the range from low to high includes it.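

The earlier compounds on this core gave no readable number, so this carbonyl carbon had shown nothing; the change from methoxycarbonyl to methylcarbamoyl now brings an at least 25-fold higher number from compound 3 to compound 4 (1.40 log units; beyond the scatter) in this assay. For the compounds shown here, compound 4 is thus the one compound of the three on the shared core to return a number, which shows that the group on this carbonyl carbon alone can lift such a compound off the limit. The size of the step remains a floor, since compound 3 stands only at a limit: the limit of < 0.0167 h in this assay, at which 2 of the 4 values shown sit.

Going by these compounds, how much of the gain belongs to the nitrogen and how much to its methyl stays open, as does whether an unsubstituted amine, dimethylamino or ethylamino on the same carbonyl carbon would last longer still. On these data alone, whether the same change holds with the 3-fluorophenyl of compound 2 also stays open.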